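This account rests on a few compounds, and the source may have more. Where it says the series, first, only, none or still open, it means among the compounds named here.

Measured so far in a functional assay on HCT-116 cells (Homo sapiens) for antiproliferative activity, read by MTT assay, with a stated time of 72 h; a lower number here means a stronger inhibitor, a higher number a weaker inhibitor:
- compound 1, `O=C(CSc1ncc[nH]1)Nc1ccc2nc(NC(=O)c3ccc(C(F)(F)F)cc3)sc2c1`: 2690 nM
- compound 2, `CCn1c(CNc2ccc(OC)cc2)nnc1SCC(=O)Nc1ccc(Cl)cc1`: 39500 nM
- compound 3, `CC(O)c1cccc(NC(=O)c2cc(Br)ccc2Br)c1`: a limit only, > 100000 nM

Among the compounds with values here, of the two numbers known in this assay, compound 1 holds the lowest, and the nearest to it is compound 2, whose number sits well beyond the scatter of repeated measurements. For compound 3 the assay reports only a limit, as described by the limit of > 100000 nM in this assay, at which 1 of the 3 values shown sits. Within the data shown here, the three measured compounds do not share a core, so no single-place step between them can be read from these data.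

Compound 4, `O=C(CSc1cccc(O)c1)Nc1ccc2nc(NC(=O)c3ccc(C(F)(F)F)cc3)sc2c1`, keeps the core of compound 1 and changes one group: 3-hydroxyphenyl in place of 1H-imidazol-2-yl on a sulfur. Among the measured compounds shown here, no measured pair mirrors this change, so its size in this assay is open. A group of similar size leaves and enters at the same sulfur, and the rest of the molecule is untouched; the change is expected to stay within the scatter, or at most a small shift toward a higher number. Compound 4 is therefore estimated at 4000 nM, with a likely range from 1000 nM to 16000 nM, which means an expected step of a 1.5-fold higher number from compound 1 to compound 4 (0.17 log units; within the scatter).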

Compound 4, half-maximal inhibitory concentration: 510 nM
Beside the measured number, compound 4's estimate is 7.8-fold (0.89 log units) above it, and the stated range ends above it.
By their numbers in this assay, from the lowest: compound 4; then compound 1; then compound 2. At a limit, above all of these: compound 3.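

Within this assay, the group on the sulfur of the shared core proves to matter: the change to 3-hydroxyphenyl in place of 1H-imidazol-2-yl gives a 5.3-fold lower number from compound 1 to compound 4 (0.72 log units; beyond the scatter), the first single-place step in this set. The carbon-only six-membered aromatic ring is thus tolerated at this position, and it gives a lower number than the five-membered ring with two hetero atoms, although both groups count the same hydrogen-bond donors and acceptors. Nothing among the data shown accounts for the size of this step.

Going by these compounds, whether the step comes from the ring itself or from its hydroxyl stays open, and a plain phenyl, a methoxyphenyl or an aminophenyl on the same sulfur would separate the two. On these data alone, how a saturated chain, such as a propyl group, would fare at this sulfur also remains unknown.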